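The source may hold more compounds than are shown below. What is called first, only, known or untested is meant among the compounds shown, and "the series" means these compounds.

In an ADME assay on the whole organism with Oryza sativa as the target, tested at 10 uM (on this read-out lower numbers stand for a stronger effect and higher numbers for a weaker effect at the one concentration tested), three compounds have been measured. Compound 1 `CCc1ccc(NC(=O)N[C@H](C)c2ccccc2)cc1` gives 44%, compound 2 `CCc1ccc(NC(=O)N[C@@H](C)c2ccccc2)cc1` gives 91%, and compound 3 `C[C@H](NC(=O)Nc1cccc(F)c1)c1ccccc1` gives 88%. Among the compounds with values here, the only single-change step among them is a number 47 percentage points higher from compound 1 to compound 2 (beyond the scatter), a shift that rests on the fact that compounds 1 and 2 differ only in the configuration as drawn alone. Compound 2 and compound 3 give numbers within the scatter of each other, while compound 1 sits far lower.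

Compound 4 `C[C@H](NC(=O)Nc1ccc(Br)cc1)c1ccccc1` is not yet measured. It differs from compound 2 by bromo in place of ethyl on an aromatic carbon, on an aromatic carbon of a six-membered aromatic ring of carbon only, para to a large group. Within the data shown here, no measured step swaps one group for another on that ring; the one measured step concerns configuration only, so it does not speak to this change. Compound 2 and compound 3, which carry different groups on that ring, give numbers within the scatter of each other. Compound 4 is therefore expected to show a number 6 percentage points lower from compound 2 to compound 4 (within the scatter), with an estimate of 85% ranging from 55% to 100%.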

Compound 4, a percentage reported as activity, at one concentration (the size of the read-out at that concentration, not a potency): 96%
Beside the measured number, compound 4's estimate is 11 percentage points below it, within the range that was stated.
By their numbers in this assay, from the lowest: compound 1; then compounds 3, 2 and 4 (each within the scatter of the next).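

Replacing ethyl with bromo on an aromatic carbon, para to a large group, gives a number 5 percentage points higher from compound 2 to compound 4 (within the scatter) in this assay. Within the data shown here, this is the first measured swap of one group for another at this position, and at the configuration of compound 2 the read-out does not tell these two groups apart, even though bromo brings a single heavy atom where ethyl has two. No available evidence bears on why this swap gives such a small step.

Among these compounds, still open is whether the same swap would also give a step within the scatter in the configuration drawn in compound 1, the only compound that stands far from the others. On these data alone, it is also open how an amine, a carboxylic acid or a longer chain such as butyl would read at this position.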